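A few compounds are considered here, and "the series" means these few. Any claim that something is new, unique, unknown or untested is made for them only; others in the source may bear on it.

Measured compounds in this set:

- compound 1, `O=c1c(-c2nnc(-c3ccc(F)cc3)o2)c[nH]c2ncc(-c3cccnc3)cc12`: 20.1%
- compound 2, `O=c1c(-c2nnc(-c3ccc(Cl)cc3)o2)c[nH]c2ncc(-c3cccnc3)cc12`: 20.1%
- compound 3, `CS(=O)(=O)c1ccc(-c2cnc3[nH]cc(-c4nnc(-c5ccc(Cl)cc5)o4)c(=O)c3c2)cc1`: 24.9%

In a functional assay on HCT-116 cells (Homo sapiens) for positive allosteric modulation, read by MTT assay, with stated times of 24 h and 48 h, tested at 2.5 uM (a lower number here means less inhibition of growth, a higher number more inhibition of growth at the concentration tested), compound 3 gives the highest of the three numbers, but its gap to compound 1 and to compound 2 is within the scatter, so the three compounds cannot be ordered on these numbers.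

Compound 4, `CS(=O)(=O)c1ccc(-c2cnc3[nH]cc(-c4nnc(-c5cccnc5)o4)c(=O)c3c2)cc1`, differs from compound 3 in one place: pyridin-3-yl in place of 4-chlorophenyl on an aromatic carbon

Among the measured compounds shown here, two measured steps bear on this. The step of no change at the digits printed from compound 1 to compound 2 (within the scatter) exchanged one halogen for another on the aryl group held on the aromatic carbon of the five-membered aromatic ring with 2 nitrogen and 1 oxygen, the same place that is altered here. The step of a number 4.8 percentage points higher from compound 2 to compound 3 (within the scatter) exchanged pyridin-3-yl for 4-(methylsulfonyl)phenyl at a different place, and was also within the scatter. For the measured compounds named here, the series so far gives no step beyond the scatter for any aryl exchange, so the expected step to compound 4 is a number 1.9 percentage points lower from compound 3 to compound 4 (within the scatter), with no direction beyond the scatter. Compound 4 is therefore estimated at 23%, in the range 12% to 34%.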

Compound 4, percent growth inhibition at one concentration: 28.6%
Estimate against measurement, compound 4: 5.6 percentage points below, and the stated range covers the measured number.
By their numbers in this assay, from the lowest: compounds 1, 2, 3 and 4 (each within the scatter of the next).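

In this assay, the step from the halogen exchange to a change of ring type at this position gives a number 3.7 percentage points higher from compound 3 to compound 4 (within the scatter), with pyridin-3-yl in place of 4-chlorophenyl on the aromatic carbon of the five-membered aromatic ring with 2 nitrogen and 1 oxygen. Earlier compounds varied only the halogen on the aryl group here; this step shows that a six-membered aromatic ring with 1 hetero atom, carrying 1 hydrogen-bond acceptor by count, can replace the all-carbon ring without a shift beyond the scatter, at least with 4-(methylsulfonyl)phenyl held constant elsewhere. Nothing at hand offers an explanation for this step.

Still open, as far as these compounds go, is whether an amine, a carboxylic acid or a longer alkyl chain on this carbon would give a step beyond the scatter. Also open, from the compounds shown here alone, is whether the same ring exchange behaves alike with pyridin-3-yl at the other varied place on the shared core.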